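Swapping a bromophenyl for a methylphenyl on the chalcone

The compounds below may be only part of what the source reports. "The series", "measured", "known", "first", "only" and "open" are said of these compounds alone.

Of the compounds shown here, three sharing one core have been measured in a functional assay on MDA-MB-231 cells (Homo sapiens) for cytotoxicity, read by MTT assay, with a stated time of 48 h; on this read-out higher numbers stand for weaker inhibition and lower numbers for stronger inhibition. Compound 1 `O=C(/C=C/c1ccc2c(c1)B(O)OC2)c1ccccc1` gives 2300 nM. Compound 2 `O=C(/C=C/c1ccc2c(c1)B(O)OC2)c1cccnc1` gives 11400 nM, and compound 3 `O=C(/C=C/c1ccc2c(c1)B(O)OC2)c1ccc(Br)cc1` gives 9500 nM. Compound 3 therefore sits at the second highest number of the three: its distance to compound 2 is within the scatter, while its distance to compound 1 is beyond it, a 4.1-fold higher number from compound 1 to compound 3 (0.62 log units; beyond the scatter).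

Compound 4 `Cc1cccc(C(=O)/C=C/c2ccc3c(c2)B(O)OC3)c1` has not yet been measured. Its difference from compound 3 is 3-methylphenyl in place of 4-bromophenyl on a carbonyl carbon. Within the data shown here, two measured steps bear on this exchange. Adding a bromine to the plain phenyl ring cost potency, a 4.1-fold higher number from compound 1 to compound 3 (0.62 log units; beyond the scatter), and swapping the ring group on the carbonyl carbon between a pyridin-3-yl and a 4-bromophenyl made no difference beyond the scatter, a 1.2-fold lower number from compound 2 to compound 3 (0.08 log units; within the scatter). Among the measured compounds shown here, a methyl group on the ring has no precedent here, so the outcome could lie anywhere between the plain phenyl of compound 1 and the bromophenyl of compound 3. The expected step in this assay is a 2.1-fold lower number from compound 3 to compound 4 (0.32 log units; beyond the scatter), a modest move toward stronger inhibition that may still fall within the scatter. Compound 4 is estimated at 4500 nM, with a range from 1500 nM to 14000 nM.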

Compound 4, half-maximal inhibitory concentration: 4500 nM
Beside the measured number, compound 4's estimate shows no gap at the digits printed, within the range that was stated.
By their numbers in this assay, from the lowest: compounds 1 and 4 (each within the scatter of the next); then compounds 3 and 2 (each within the scatter of the next).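

In this assay, compound 4 shows that a group added to the plain phenyl ring on the carbonyl carbon need not shift the number beyond the scatter: methyl in place of hydrogen gives a 2.0-fold higher number from compound 1 to compound 4 (0.29 log units; within the scatter), whereas bromo in place of hydrogen had given a 4.1-fold higher number from compound 1 to compound 3 (0.62 log units; beyond the scatter). The new group also separates itself from the two weaker compounds, with 3-methylphenyl in place of 4-bromophenyl giving a 2.1-fold lower number from compound 3 to compound 4 (0.32 log units; beyond the scatter) and 3-methylphenyl in place of pyridin-3-yl giving a 2.5-fold lower number from compound 2 to compound 4 (0.40 log units; beyond the scatter), both modest steps toward stronger inhibition. No measurement shown here accounts for these differences.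

The names 3-methylphenyl and 4-bromophenyl differ in both the group and its numbered place on the ring, so these compounds cannot tell whether the kind of group or its place matters more. From the compounds shown here alone, how a methoxy group, an amine or a carboxylic acid on this ring would behave also remains open, as does whether any ring group on the carbonyl carbon can give a clearly lower number than the plain phenyl of compound 1.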